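From 4-chlorophenyl to trifluoromethyl in compound 1

The source may hold more compounds than are shown below. What is called first, only, known or untested is meant among the compounds shown, and "the series" means these compounds.

Compound 1 `CC(=O)c1ccc(NC(=O)Cn2nc(-c3ccc(Cl)cc3)nc2N)cc1` gives 8.53%
Compound 2 `C/C(=N\O)c1ccc(NC(=O)Cn2nc(-c3ccc(Cl)cc3)nc2N)cc1` gives 10.7%
Compound 3 `C/C(=N/O)c1ccc(NC(=O)Cn2nc(-c3ccccc3)nc2N)cc1` gives 3.56%

In a functional assay on SNB-19 cells (Homo sapiens) for inhibition, read by sulforhodamine B assay, with a stated time of 48 h, tested at 10 uM (a higher number here means more inhibition of growth at the concentration tested, a lower number less inhibition of growth), compound 1 stands at 8.53% and lies within the scatter of both compound 2 and compound 3, so no order can be read among these values. Compound 4 `CC(=O)c1ccc(NC(=O)Cn2nc(C(F)(F)F)nc2N)cc1` keeps the rest of compound 1 but carries trifluoromethyl in place of 4-chlorophenyl on an aromatic carbon. For the measured compounds named here, the one measured step of a number 2.2 percentage points higher from compound 1 to compound 2 (within the scatter) is small and concerns another part of the molecule, so it bears only indirectly on this change. Going by the values given here, no measured pair isolates the loss of 4-chlorophenyl, which leaves little ground for predicting a shift in either direction. An expected a number 2.5 percentage points lower from compound 1 to compound 4 (within the scatter) would stay within the scatter in this assay as far as can be judged. Compound 4 is estimated at 6% with a range from -4% to 18% expected.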

Compound 4, percent growth inhibition at one concentration: 4.37%
Beside the measured number, compound 4's estimate is 1.6 percentage points above it; measured number inside the range.
By their numbers in this assay, from the lowest: compounds 3, 4, 1 and 2 (each within the scatter of the next).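

In this assay, putting trifluoromethyl in place of 4-chlorophenyl on the aromatic carbon gives a number 4.2 percentage points lower from compound 1 to compound 4 (within the scatter). For the compounds shown here, this is the first measured exchange of the whole 4-chlorophenyl group at this position, and it shows that a group with no ring and fewer heavy atoms leaves compound 4 indistinguishable from compound 1 in this read-out. Nothing available accounts for this result or says what the group at this position contributes.

Going by these compounds, it remains open whether any group at this position can move growth inhibition beyond the scatter, since both groups compared here give low values. A carboxylic acid, an amine or a longer alkyl chain on this aromatic carbon could test that, at concentrations other than the single one used here.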